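Dropping the Trifluoromethyl Group from the Anilide

The source may report more compounds than this note shows. Statements on the series, on what has been measured and on what is new or still open speak of the compounds shown alone.

Compound 1, `COc1ccc(-n2nc(C(N)=O)nc2-c2cc(OC)c(OC)c(OC)c2)cc1`: 92%
Compound 2, `COc1ccc(-n2nc(C(=O)Nc3cccc(F)c3)nc2-c2cc(OC)c(OC)c(OC)c2)cc1`: 92%
Compound 3, `COc1ccc(-n2nc(C(=O)Nc3ccc(C(F)(F)F)cc3)nc2-c2cc(OC)c(OC)c(OC)c2)cc1`: 83%

In a functional assay on the whole organism for inhibition, with Rattus norvegicus as the target, read by paw edema, with stated times of 30 min and 3 h, at a dose of 0.28 mmol/kg by the oral route (on this read-out lower numbers stand for less inhibition and higher numbers for more inhibition at the one dose given (going by the name of the read-out)), compound 3 gives 83%, the lowest of the three numbers, yet both other compounds stand within the scatter of it, so no order among the three can be claimed. Compound 4, `COc1ccc(-n2nc(C(=O)Nc3ccccc3)nc2-c2cc(OC)c(OC)c(OC)c2)cc1`, differs from compound 3 by hydrogen in place of trifluoromethyl on an aromatic carbon. Going by the values given here, two measured steps bear on this change, since both put an aryl group on the amide nitrogen and end at compound 3: a number 9 percentage points lower from compound 1 to compound 3 (within the scatter), and a number 9 percentage points lower from compound 2 to compound 3 (within the scatter). Neither moves the read-out beyond the scatter, and the substituent on that aryl ring has not separated compound 2 from compound 3 either. The expected step in this assay is therefore a number 5 percentage points higher from compound 3 to compound 4 (within the scatter), none beyond the scatter, if anything a drift back toward the numbers of compound 1 and compound 2. Compound 4 is estimated at 88%, with a range from 78% to 96%.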

Compound 4, a percentage reported as inhibition, in the whole organism at one dose (the size of the read-out at that dose, not a potency): 69%
Compound 4: middle estimate off by 19 percentage points, on the high side, and the stated range ends above it.
By their numbers in this assay, from the lowest: compound 4; then compounds 3, 1 and 2 (each within the scatter of the next).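

In this assay, going by these compounds alone, the phenyl anilide is the first compound to separate from the others: a number 14 percentage points lower from compound 3 to compound 4 (beyond the scatter) on removing trifluoromethyl, and a number 23 percentage points lower from compound 2 to compound 4 (beyond the scatter) on removing fluoro. A phenyl group on the amide nitrogen is therefore not interchangeable with the amide hydrogen, a number 23 percentage points lower from compound 1 to compound 4 (beyond the scatter), even though the fluorine-bearing aryl groups of compound 2 and compound 3 had shown no such separation from compound 1. Nothing available accounts for this difference.

The compounds shown leave open whether a methyl, methoxy or amino group on the same ring would match fluoro and trifluoromethyl, or whether only those fluorine-bearing groups do this. They also leave open whether a benzyl group on the amide nitrogen would behave like the phenyl of compound 4 or the amide hydrogen of compound 1.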